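This account rests on a few compounds, and the source may have more. Where it says the series, first, only, none or still open, it means among the compounds named here.

Measured compounds:
Compound 1, `COc1ccc(-n2cc(COc3c(/C=C\C(=O)O)ccc(OC)c3CC=C(C)C)nn2)cc1` — "not determined" (no result reported).
Compound 2, `COc1ccc(/C=C\C(=O)O)c(OCc2cn(-c3cccnc3Cl)nn2)c1CC=C(C)C` — 32600 nM.

Two compounds share the same core, and only one of them carries a number. Compound 1 has the structure `COc1ccc(-n2cc(COc3c(/C=C\C(=O)O)ccc(OC)c3CC=C(C)C)nn2)cc1` and for compound 1 the result came back as "not determined" (no result reported). Compound 2 has the structure `COc1ccc(/C=C\C(=O)O)c(OCc2cn(-c3cccnc3Cl)nn2)c1CC=C(C)C` and, in a functional assay on A-431 cells (Homo sapiens) for cytotoxicity, read by MTT assay, with a stated time of 24 h (on this read-out higher numbers stand for weaker inhibition and lower numbers for stronger inhibition), compound 2 gives 32600 nM, which is the only figure available and a weak one on this read-out.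

The next compound keeps everything on the core and changes only the group on the triazole nitrogen. Compound 3 has the structure `COc1ccc(/C=C\C(=O)O)c(OCc2cn(-c3nc4ccccc4s3)nn2)c1CC=C(C)C`. Compared with compound 2, the change is 1,3-benzothiazol-2-yl in place of 2-chloropyridin-3-yl on an aromatic nitrogen.

Within the data shown here, no pair of measured compounds shows what such a swap does here, so there is no step to lean on. With only the weak figure for compound 2 to go by, the expected step from compound 2 to compound 3 is a 1.3-fold lower number from compound 2 to compound 3 (0.12 log units; within the scatter), in no clear direction and not beyond the usual scatter. Compound 3 is therefore estimated at 25000 nM in this assay, with a plausible range from 8000 nM to 80000 nM.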

Compound 3, half-maximal inhibitory concentration: 20800 nM
Compound 3: middle estimate off by 1.2-fold (0.08 log units), on the high side; the range from low to high includes it.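

In this assay, placing 1,3-benzothiazol-2-yl instead of 2-chloropyridin-3-yl on the aromatic nitrogen gives a 1.6-fold lower number from compound 2 to compound 3 (0.20 log units; within the scatter), so the two compounds cannot be told apart on this read-out. Among these compounds, this is the first measured comparison at this position, and it shows that exchanging one aromatic ring for two, with sulfur in place of chlorine and a second hydrogen-bond acceptor in the group, leaves the number within ordinary measurement noise, and both figures remain weak. Nothing measured separately here explains why the swap has so little effect on the number, and with a single pair a real but small effect cannot be ruled out either.

Among the compounds shown here, compound 1 has no number, so no step involving it can be read, and the 4-methoxyphenyl group it carries at this position remains untested as a comparison. Going by these compounds, it also remains open whether a simple butyl chain or a chain ending in an amine on this nitrogen would move the number beyond the scatter, and whether a methyl ester in place of the carboxylic acid on the shared core would do so.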